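Sulfur in Place of Oxygen on the Dichlorophenyl Linker

A few compounds are considered here, and "the series" means these few. Any claim that something is new, unique, unknown or untested is made for them only; others in the source may bear on it.

Compound 1 `Nc1cc(N)c2nc(-c3ccccc3)c(Oc3ccc(Cl)c(Cl)c3)nc2c1` gives, in a functional assay on RXF 393 cells (Homo sapiens) for inhibition, read by sulforhodamine B assay, with a stated time of 48 h (a higher number here means that more compound is tolerated, a lower number that less compound is tolerated), only the limit < 100000 nM.
Compound 2 `CCOC(=O)[C@H](CCC(=O)O)NC(=O)c1ccc(Sc2nc3cc(N)cc(N)c3nc2-c2ccccc2)cc1` likewise reaches only the limit < 100000 nM in this assay.
Compound 3 `Nc1cc(N)c2nc(-c3ccccc3)c(Sc3ccc(F)cc3)nc2c1` also stops at the limit < 100000 nM in this assay.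

Compound 1 therefore stands at the limit of < 100000 nM in this assay, at which 3 of the 3 values shown sit, and nothing separates it from the other two on the numbers shown. The change from compound 1 to compound 4 `Nc1cc(N)c2nc(-c3ccccc3)c(Sc3ccc(Cl)c(Cl)c3)nc2c1` is (3,4-dichlorophenyl)sulfanyl in place of 3,4-dichlorophenoxy on an aromatic carbon. Within the data shown here, the only measured step, a step that the two limits leave unreadable from compound 1 to compound 3, alters both the halogen pattern and the linking atom. Its size stays hidden behind the limits. Among the measured compounds shown here, no measured step thus gives a size for this change. Compound 4 is expected to remain at the limit as well, the expected step being a step that the limit leaves unreadable from compound 1 to compound 4. Compound 4 is estimated at 50000 nM, with a range from 10000 nM to 100000 nM.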

Compound 4, concentration lethal to 50% of the cells: 60300 nM
Compound 4: middle estimate off by 1.2-fold (0.08 log units), on the low side; measured number inside the range.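

The steps from compound 1 and from compound 3 to compound 4 cannot be read, as each starts from a limit: the limit of < 100000 nM in this assay, at which 3 of the 4 values shown sit.

From the compounds shown here alone, whether (3,4-dichlorophenyl)sulfanyl in place of 3,4-dichlorophenoxy shifts the lethal concentration at all, and by how much, stays open.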